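A few compounds are considered here, and "the series" means these few. Any claim that something is new, unique, unknown or untested is made for them only; others in the source may bear on it.

Measured so far in a functional assay on CCRF-CEM cells (Homo sapiens) for antiproliferative activity, read by cell counting, with a stated time of 96 h; a higher number here means a weaker inhibitor, a lower number a stronger inhibitor:
- compound 1 `CC(=O)c1ccc(Oc2ccccc2NC(C)=C2C(=O)CC(c3ccccc3)CC2=O)cc1` gives 220 nM
- compound 2 `CCOc1ccccc1NC(C)=C1C(=O)CC(c2ccccc2)CC1=O` gives 190 nM

Among the compounds with values here, compound 2 (190 nM) lies within the scatter of compound 1 (220 nM), the only other compound measured, so the two cannot be ranked. Next comes compound 3 `COc1cccc(Oc2ccccc2NC(C)=C2C(=O)CC(c3ccccc3)CC2=O)c1`, which differs from compound 2 in one place: 3-methoxyphenyl in place of ethyl on an oxygen on an aromatic ring. In words, this is 3-methoxyphenyl in place of ethyl on an oxygen on an aromatic ring.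

Within the data shown here, one measured step bears on this change: a 1.2-fold lower number from compound 1 to compound 2 (0.06 log units; within the scatter), with ethyl in place of 4-acetylphenyl on that same oxygen. That step is small, so ethyl and one group carrying an aromatic ring are not told apart here. Among the measured compounds shown here, it is a single comparison, however, and no measured compound carries a methoxy group on that ring. No shift beyond the scatter is therefore expected in this assay, and the expected change is a 1.1-fold higher number from compound 2 to compound 3 (0.04 log units; within the scatter) in size. Compound 3 is estimated at 210 nM, with an expected range from 90 nM to 480 nM in this estimate.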

Compound 3, half-maximal inhibitory concentration: 41 nM
Beside the measured number, compound 3's estimate is 5.1-fold (0.71 log units) above it; the measured number lies below the stated range.
By their numbers in this assay, from the lowest: compound 3; then compounds 2 and 1 (each within the scatter of the next).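

In this assay, the group on this oxygen proves able to shift the number beyond the scatter: with 3-methoxyphenyl in place of ethyl, the result is (a 4.6-fold lower number from compound 2 to compound 3 (0.67 log units; beyond the scatter)), and with 3-methoxyphenyl in place of 4-acetylphenyl, it is (a 5.4-fold lower number from compound 1 to compound 3 (0.73 log units; beyond the scatter)). The earlier pair could not separate ethyl from 4-acetylphenyl, so an aromatic ring on this oxygen does not by itself set a compound apart: compound 1 carries one and remains within the scatter of compound 2, while compound 3 stands clear of both. Nothing available here accounts for the difference that 3-methoxyphenyl makes.

The compounds shown leave open whether the methoxy group, its place on the ring, or both set compound 3 apart, as 3-methoxyphenyl and 4-acetylphenyl differ in the group as well as in its numbered place. Going by these compounds, how an unsubstituted phenyl, a 4-methoxyphenyl, or a 3-aminophenyl on this oxygen would compare also remains open, as does whether a longer chain in place of ethyl would move the number at all.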